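The source may report more compounds than this note shows. Statements on the series, on what has been measured and on what is new or still open speak of the compounds shown alone.

Compound 1 `Nc1ccccc1NC(=O)c1ccc(CSC(=S)N2CCN(c3cccnc3)CC2)cc1` is the stronger of the two compounds that have so far been tested in a functional assay on HeLa cells (Homo sapiens) for antiproliferative activity, read by CCK-8 assay, with a stated time of 72 h, tested at 8 uM (a lower number here means a weaker effect, a higher number a stronger effect of the compound at the concentration tested), where compound 1 gives 72.5%. The other measured compound, compound 2 `Nc1ccccc1NC(=O)c1ccc(CSC(=S)N2CCCc3ccccc32)cc1`, was run in the same way, and in this assay compound 2 gives 35.7%, a number far enough below that of compound 1 for the gap to lie beyond the usual scatter of this kind of measurement. Nothing is known about how a single change to compound 1 shifts the read-out. Compound 1 and compound 2 differ in more than one place.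

The compound not yet measured, compound 3 `Nc1ccccc1NC(=O)c1ccc(CSC(=S)N2CCN(c3ccncc3)CC2)cc1`, is built from the same atoms as compound 1, joined differently: pyridin-4-yl in place of pyridin-3-yl on an amine nitrogen in a ring. Both compounds carry the same ring with its one nitrogen, only attached through a different ring carbon. The step in this assay is expected to be small, in no clear direction, and within the scatter. The step of a number 4.5 percentage points lower from compound 1 to compound 3 (within the scatter) is the expected outcome. Compound 3 is therefore estimated at 68%, with a range from 48% to 85%.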

Compound 3, a percentage reported as inhibition, at one concentration (the size of the read-out at that concentration, not a potency): 77.4%
Estimate against measurement, compound 3: 9.4 percentage points below, and the stated range covers the measured number.
By their numbers in this assay, from the lowest: compound 2; then compounds 1 and 3 (each within the scatter of the next).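

Going by these compounds alone, putting pyridin-4-yl in place of pyridin-3-yl on an amine nitrogen in a ring gives a number 4.9 percentage points higher from compound 1 to compound 3 (within the scatter) in this assay, and this is the first change at a single place that can be read. Moving the attachment to a different ring carbon, with the atoms and the counted donors and acceptors unchanged, therefore gives two compounds that this assay cannot tell apart, so at this position the choice between these two groups makes no visible difference to the read-out. Nothing measured here offers an explanation for this result.

The compounds shown leave open whether the read-out would also hold with pyridin-2-yl, with a plain phenyl ring carrying no ring nitrogen, or with a small group such as methyl on the same nitrogen, any of which would test how much of the ring this position needs. Each number is also a percentage at one concentration rather than a potency, so a difference between compound 1 and compound 3 could still appear at other concentrations.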